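The source may report more compounds than this note shows. Statements on the series, on what has been measured and on what is new or still open speak of the compounds shown alone.

Compound 1 `Cc1n[nH]c2ccc(-c3nc4cnc(N5CCN(C)CC5)cn4c3Nc3ccc(F)cc3)cc12` and compound 2 `Cc1n[nH]c2ccc(-c3nc4cnc(N5CCN(C)CC5)cn4c3Nc3ccccc3)cc12` were both tested in a functional assay on MV4-11 cells (Homo sapiens) for inhibition, with a stated time of 120 h, tested at 10 uM; a lower number here means less inhibition, a higher number more inhibition at the concentration tested (going by the name of the read-out). In this assay compound 1 gives 0%, and compound 2 gives 0%. For the measured compounds named here, the one measured step, no change at the digits printed from compound 1 to compound 2 (within the scatter), is a hydrogen in place of fluoro on an aromatic carbon, and it left the read-out unchanged within the scatter. Compound 2 therefore stands level with compound 1 at the digits shown, with neither compound showing inhibition at the concentration tested.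

Compound 3 `Cc1ccc(C)c(Nc2c(-c3ccc4[nH]nc(C)c4c3)nc3cnc(N4CCN(C)CC4)cn23)c1` is the next compound. It differs from compound 2 by 2,5-dimethylphenyl in place of phenyl on a nitrogen on an aromatic ring. Going by the values given here, the only measured step, from compound 1 to compound 2, concerns a different kind of change and was flat, so it gives no sign that a substituent on the group attached to that nitrogen moves the read-out. With both measured compounds at zero, the expected step of a number 5 percentage points higher from compound 2 to compound 3 (within the scatter) is small, and any movement would have to be upward since the read-out cannot fall further. The estimate for compound 3 in this assay is 5%, within a range from 0% to 25%.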

Compound 3, a percentage reported as inhibition, at one concentration (the size of the read-out at that concentration, not a potency): 0%
Beside the measured number, compound 3's estimate is 5 percentage points above it, and the stated range covers the measured number.
By their numbers in this assay, from the lowest: compounds 1, 2 and 3 (each within the scatter of the next).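

Putting 2,5-dimethylphenyl in place of phenyl on the nitrogen gives no change at the digits printed from compound 2 to compound 3 (within the scatter) in this assay, and putting it in place of 4-fluorophenyl gives no change at the digits printed from compound 1 to compound 3 (within the scatter). This extends the picture from a single fluoro swap to a larger change on the same ring: phenyl, 4-fluorophenyl and 2,5-dimethylphenyl on this nitrogen all give the same printed read-out, with compound 3 at 0%, so none of the three shows inhibition at the concentration tested. Nothing measured alongside these numbers accounts for the flat result.

With all three compounds at zero, this read-out cannot rank them, and it cannot show whether a change on this nitrogen would lower inhibition, since there is none to lose. Still open, from the compounds shown here alone, is whether a quite different group there, such as a pyridine ring, a saturated cyclohexyl ring or a benzyl group, would lift the read-out above zero, or whether a change elsewhere on the shared core would be needed.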